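Pyridyl Swap on the Shared Core of Compound 3

This account rests on a few compounds, and the source may have more. Where it says the series, first, only, none or still open, it means among the compounds named here.

Compound 1, `N#Cc1cc(Cl)ccc1NC(=O)c1ccc2cccnc2c1O`: 790 nM
Compound 2, `O=C(Nc1ccc(Br)c(Cl)c1)c1cc(F)ccc1O`: 600 nM
Compound 3, `N#Cc1ccc(NC(=O)c2cc(-c3ccncc3)ccc2O)cc1`: 5410 nM

All three were tested in a functional assay on HL-60 cells (Homo sapiens) for cytotoxicity, read by luminescence and CellTiter-Glo, with a stated time of 3 days; a higher number here means a weaker inhibitor, a lower number a stronger inhibitor. Compound 3 gives the highest of the three numbers; the nearest value belongs to compound 1, the furthest to compound 2, and both gaps lie beyond the scatter. Among the compounds with values here, no pair among the measured compounds differs in just one place, so no single step can be read off.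

Compound 4, `N#Cc1ccc(NC(=O)c2cc(-c3cccnc3)ccc2O)cc1`, differs from compound 3 in one place: pyridin-3-yl in place of pyridin-4-yl on an aromatic carbon. Within the data shown here, nothing among the measured compounds speaks directly to this change. The author therefore expects a step of a 1.2-fold lower number from compound 3 to compound 4 (0.08 log units; within the scatter), one that should not reach beyond the scatter in either direction. Compound 4 is expected to give 4500 nM, most likely between 1500 nM and 14000 nM.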

Compound 4, half-maximal inhibitory concentration: 7960 nM
The estimate for compound 4 lay 1.8-fold (0.25 log units) below the measured number, and the stated range covers the measured number.
By their numbers in this assay, from the lowest: compounds 2 and 1 (each within the scatter of the next); then compounds 3 and 4 (each within the scatter of the next).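

Within the data shown here, replacing pyridin-4-yl with pyridin-3-yl on the aromatic carbon para to the hydroxy group gives a 1.5-fold higher number from compound 3 to compound 4 (0.17 log units; within the scatter) in this assay, and this is the first single-place comparison available. At this position, the two pyridine attachments cannot be told apart, so moving the ring nitrogen has no effect that can be distinguished from the scatter. Nothing available bears on why this is so. The compounds shown leave open whether pyridin-2-yl, a phenyl ring, an amine or a carboxylic acid at this carbon would change the number beyond the scatter.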